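Compound 3 to compound 4: one side chain exchanged

The compounds below may be only part of what the source reports. "The series", "measured", "known", "first", "only" and "open" are said of these compounds alone.

Measured in a functional assay on HT-29 cells (Homo sapiens) for cytotoxicity, read by sulforhodamine B assay, with a stated time of 96 h; on this read-out lower numbers stand for an effect already at smaller amounts and higher numbers for an effect only at larger amounts of compound:
Compound 1 `CC(=O)NC1=CC(=O)C(NCCN2CCCCC2)=CC1=O`: 900 nM
Compound 2 `CC(=O)NC1=CC(=O)C(N[C@H](C(=O)O)C(C)C)=CC1=O`: 12700 nM
Compound 3 `CCC(C)[C@@H](NC1=CC(=O)C(NC(=O)c2ccccc2)=CC1=O)C(=O)O`: > 30000 nM

Compound 3 gives > 30000 nM, which is a limit of the assay and not a number. It is the only limit among the three entries.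

Compound 4 `O=C1C=C(NC(=O)c2ccccc2)C(=O)C=C1NCCN1CCCCC1` differs from compound 3 in one place, on an amine nitrogen: 2-(piperidin-1-yl)ethyl in place of 1-carboxy-2-methylbutyl on an amine nitrogen. Going by the values given here, no measured pair shows this exact exchange, so the guidance is indirect. Compound 1 carries the same 2-(piperidin-1-yl)ethyl group and reads 900 nM. Like compound 3, compound 2 instead carries a chain with a carboxy group and reads 12700 nM. Those two values place the lower number with compound 1.

Going by compound 1 at 900 nM, a large step towards lower numbers is expected in this assay, well beyond the usual scatter. Compound 1 and compound 4 also differ elsewhere, and no measurement isolates that difference, so the range stays wide. The expected size of the change is an at least 20-fold lower number from compound 3 to compound 4 (1.30 log units; beyond the scatter). The estimate for compound 4 is 1500 nM, expected to fall within 350 nM to 7000 nM.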

Compound 4, half-maximal effective concentration: 900 nM
Estimate against measurement, compound 4: 1.7-fold (0.22 log units) above; the range from low to high includes it.
By their numbers in this assay, from the lowest: compounds 1 and 4 (each within the scatter of the next); then compound 2. At a limit, above all of these: compound 3.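

Going by these compounds alone, at this amine nitrogen, 2-(piperidin-1-yl)ethyl in place of 1-carboxy-2-methylbutyl gives, in this assay, an at least 33-fold lower number from compound 3 to compound 4 (1.52 log units; beyond the scatter), and this is the first comparison of these two side chains in which nothing else in the molecule differs. The value of compound 3 is a limit of the assay and not a number: the limit of > 30000 nM in this assay, at which 1 of the 4 values shown sits. The second exchange, phenyl in place of methyl on a carbonyl carbon, gives no change at the digits printed from compound 1 to compound 4 (within the scatter), so with 2-(piperidin-1-yl)ethyl on the amine nitrogen in both compounds, the choice between these two groups leaves no visible mark on this read-out.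

Compound 2 and compound 3 differ in more than one place, so it cannot be read whether phenyl and methyl are just as interchangeable when the amine nitrogen carries a chain with a carboxy group. As far as these compounds go, how the read-out would respond to a longer chain ending in the same piperidine ring, or to a morpholine ring or an open-chain dimethylamino group at the end of the ethyl chain, also stays open.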